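Replacing one aromatic group on compound 3

The source may report more compounds than this note shows. Statements on the series, on what has been measured and on what is new or still open speak of the compounds shown alone.

In a physicochemical assay for lipophilicity (a lower number here means a more polar compound, a higher number a more lipophilic compound), compound 3 (`O=S(=O)(Nc1ccncn1)c1ccc2c(c1)OCC[C@@H]2c1ccc(C(F)(F)F)cc1-c1ccc(F)cn1`) gives 3, the middle of three numbers: compound 1 (`Cn1nccc1-c1cc(C(F)(F)F)ccc1[C@H]1CCOc2cc(S(=O)(=O)Nc3cccc(F)n3)ccc21`) gives 3.6 and compound 2 (`Cn1nccc1-c1cc(C(F)(F)F)ccc1[C@H]1CCOc2cc(S(=O)(=O)Nc3cnccn3)ccc21`) gives 1.8. Compound 4 (`Cn1nccc1-c1cc(C(F)(F)F)ccc1[C@H]1CCOc2cc(S(=O)(=O)Nc3ccncn3)ccc21`) differs from compound 3 in one group: 1-methyl-1H-pyrazol-5-yl in place of 5-fluoropyridin-2-yl on an aromatic carbon. This puts 1-methyl-1H-pyrazol-5-yl in place of 5-fluoropyridin-2-yl on an aromatic carbon. Within the data shown here, no measured step makes this swap. Among the measured compounds shown here, the only measured step, a number 1.80 log units lower from compound 1 to compound 2 (beyond the scatter), is large, but it changes the group on the sulfonamide nitrogen, so it bears only indirectly. Both of its compounds already carry the entering group, and compound 2 resembles compound 4 more closely on that nitrogen. A moderate fall is therefore expected, a number 0.70 log units lower from compound 3 to compound 4 (beyond the scatter). Compound 4 is estimated at 2.3, within a range from 1.8 to 2.8.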

Compound 4, distribution coefficient: 1.8
The estimate for compound 4 lay 0.50 log units above the measured number, within the range that was stated.
By their numbers in this assay, from the lowest: compounds 2 and 4 (each within the scatter of the next); then compound 3; then compound 1.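

In this assay the aromatic carbon ortho to a large group proves sensitive: 1-methyl-1H-pyrazol-5-yl in place of 5-fluoropyridin-2-yl gives a number 1.20 log units lower from compound 3 to compound 4 (beyond the scatter) as a large step. On the sulfonamide nitrogen, pyrimidin-4-yl in place of pyrazin-2-yl gives no change at the digits printed from compound 2 to compound 4 (within the scatter) and stays within the scatter, while pyrimidin-4-yl in place of 6-fluoropyridin-2-yl gives a number 1.80 log units lower from compound 1 to compound 4 (beyond the scatter) as another large step. Nothing measured here gives a cause for these steps.

From the compounds shown here alone, whether the aromatic swap gives the same step with another group on the sulfonamide nitrogen remains open. So does how an amine or a carboxylic acid on that aromatic carbon would read.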